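The compounds below may be only part of what the source reports. "The series", "measured", "known", "first", "only" and "open" are said of these compounds alone.

Measured so far:
compound 1 `O=C(CCC1=CCN(CCCc2ccc(Br)cc2)C1=O)NO` 2520 nM
compound 2 `CCOc1ccc(CCCN2CC=C(CCC(=O)NO)C2=O)cc1` 2520 nM
compound 3 `Cc1ccccc1CCCN1CC=C(CCC(=O)NO)C1=O` 2520 nM

In a functional assay on NCI-H23 cells (Homo sapiens) for inhibition, read by sulforhodamine B assay (a lower number here means a stronger inhibitor of growth, a higher number a weaker inhibitor of growth), compound 3 gives 2520 nM, level with compound 1 and compound 2 at the digits shown. Compound 4 `Cc1ccc(CCCN2CC=C(CCC(=O)NO)C2=O)cc1` is not yet measured; it differs from compound 3 in one place: 4-methylphenyl in place of 2-methylphenyl on a saturated chain carbon, three bonds along the chain from an amide-type nitrogen in a ring. Among the measured compounds shown here, two measured steps bear on this change of the aryl group. The step from compound 1 to compound 2 gave no change at the digits printed from compound 1 to compound 2 (within the scatter), and the step from compound 1 to compound 3 gave no change at the digits printed from compound 1 to compound 3 (within the scatter); neither the aromatic substituent nor its position moved the number. Compound 4 is therefore expected to show no change at the digits printed from compound 3 to compound 4 (within the scatter), no step beyond the scatter. Compound 4 is estimated at 2520 nM in this assay, with a range from 1260 nM to 5040 nM.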

Compound 4, concentration for 50% growth inhibition: 2520 nM
Beside the measured number, compound 4's estimate shows no gap at the digits printed; low and high end bracket the measured number.
By their numbers in this assay, from the lowest: compounds 1, 2, 3 and 4 (each within the scatter of the next).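

In this assay, among the compounds shown here, 4-methylphenyl in place of 2-methylphenyl gives no change at the digits printed from compound 3 to compound 4 (within the scatter), the first direct comparison of one substituent at two places on the aryl group. Methyl in place of ethoxy gives no change at the digits printed from compound 2 to compound 4 (within the scatter) and methyl in place of bromo gives no change at the digits printed from compound 1 to compound 4 (within the scatter), so these three aromatic substituents now compare directly, with no step beyond the scatter. No evidence is available to explain this flat result.

The compounds shown leave open whether an amine or a carboxylic acid on the aromatic ring, or a longer chain in place of the saturated chain carrying the aryl group, would move the number.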